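A methoxy placed on the phenyl ring of compound 3

The source may report more compounds than this note shows. Statements on the series, on what has been measured and on what is new or still open speak of the compounds shown alone.

Measured compounds in a functional assay (plasma) with Oryctolagus cuniculus as the target; a higher number here means a weaker inhibitor, a lower number a stronger inhibitor:
compound 1, `Cc1nc2cnccc2n1CC1CCN(C(=O)CC(C)c2ccccc2)CC1`, 12 nM
compound 2, `CCCC(CC(=O)N1CCC(Cn2c(C)nc3cnccc32)CC1)c1ccccc1`, 11 nM
compound 3, `Cc1nc2cnccc2n1CC1CCN(C(=O)CCc2ccccc2)CC1`, 60 nM

Compound 3 stands at the highest of the three numbers in this assay: the step of a 5.0-fold higher number from compound 1 to compound 3 (0.70 log units; beyond the scatter) and the step of a 5.5-fold higher number from compound 2 to compound 3 (0.74 log units; beyond the scatter) are both beyond the scatter, so compound 3 is the weakest inhibitor of the three, while compound 1 and compound 2 lie within the scatter of each other, as a 1.1-fold lower number from compound 1 to compound 2 (0.04 log units; within the scatter) shows.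

Compound 4, `COc1ccccc1CCC(=O)N1CCC(Cn2c(C)nc3cnccc32)CC1`, differs from compound 3 in one place: methoxy in place of hydrogen on an aromatic carbon. Going by the values given here, none of the measured steps touches the phenyl ring; all three concern the saturated chain carbon bound to an aromatic carbon and a saturated chain carbon. The data therefore carry no direct guide for a methoxy on the ring. With nothing to point either way, the step of no change at the digits printed from compound 3 to compound 4 (within the scatter) is expected to stay within the scatter. Compound 4 is thus estimated at 60 nM in this assay, with a range from 20 nM to 180 nM.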

Compound 4, half-maximal inhibitory concentration: 15 nM
For compound 4 the middle estimate is 4.0-fold (0.60 log units) above the measured one; measured number below the stated range.
By their numbers in this assay, from the lowest: compounds 2, 1 and 4 (each within the scatter of the next); then compound 3.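

In this assay, the change on the phenyl ring itself moves the number (2-methoxyphenyl in place of phenyl: a 4.0-fold lower number from compound 3 to compound 4 (0.60 log units; beyond the scatter)), so this aromatic carbon, ortho to a large group, responds to substitution, which the steps on the saturated chain carbon could not show. A methoxy on the ring also brings compound 3 level with the chain-substituted compounds, within the scatter of both (a 1.3-fold higher number from compound 1 to compound 4 (0.10 log units; within the scatter); a 1.4-fold higher number from compound 2 to compound 4 (0.13 log units; within the scatter)). Nothing measured here accounts for this step.

From the compounds shown here alone, it remains open whether a hydroxy, a chlorine or an ethoxy at this same aromatic carbon would behave like the methoxy, and whether a methoxy on another ring carbon would do the same. Also open, going by these compounds, is whether the methoxy and the chain methyl of compound 1 would add up when carried on one molecule.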